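The source may report more compounds than this note shows. Statements on the series, on what has been measured and on what is new or still open speak of the compounds shown alone.

Measured so far:
- compound 1 `Cc1ccc(-c2nn(-c3ccccc3)cc2-c2nc3ccccc3n2S(=O)(=O)c2ccc(F)cc2)cc1`: 5270 nM
- compound 2 `Cc1ccc(C)c(S(=O)(=O)n2c(-c3cn(-c4ccccc4)nc3-c3ccc(F)cc3)nc3ccccc32)c1`: 430 nM

Both values come from a functional assay on MCF7 cells (Homo sapiens) for antiproliferative activity, read by MTT assay, with a stated time of 24 h; on this read-out lower numbers stand for stronger inhibition and higher numbers for weaker inhibition. Compound 2 holds the lower of the two numbers, and its gap to compound 1 lies beyond the scatter. Compound 3 `O=S(=O)(c1ccc(F)cc1)n1c(-c2cn(-c3ccccc3)nc2-c2ccc(F)cc2)nc2ccccc21` is not yet measured and differs from compound 2 as follows: 4-fluorophenyl in place of 2,5-dimethylphenyl on a sulfonyl sulfur. Compound 1 also carries 4-fluorophenyl on a sulfonyl sulfur and gives 5270 nM, so a move to a higher number, beyond the scatter, is expected. The expected move is a 4.2-fold higher number from compound 2 to compound 3 (0.62 log units; beyond the scatter). For compound 3 the estimated value is 1800 nM, with an expected range of 400 nM to 6500 nM.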

Compound 3, half-maximal inhibitory concentration: 3670 nM
Compound 3: the middle estimate sits 2.0-fold (0.31 log units) below what was measured; low and high end bracket the measured number.
By their numbers in this assay, from the lowest: compound 2; then compounds 3 and 1 (each within the scatter of the next).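

In this assay, 4-fluorophenyl in place of 2,5-dimethylphenyl on a sulfonyl sulfur gives an 8.5-fold higher number from compound 2 to compound 3 (0.93 log units; beyond the scatter), so this position responds to the change while the rest of the molecule stays fixed. The other single change, fluoro in place of methyl on an aromatic carbon, gives a 1.4-fold lower number from compound 1 to compound 3 (0.16 log units; within the scatter) and so stays within the scatter. Nothing measured here accounts for the sulfonyl step. As far as these compounds go, whether compound 2 owes its lower number to one methyl or to both remains open. From the compounds shown here alone, how a methoxy group or an amine on that phenyl ring would read also remains open.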